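From pyridin-4-yl to pyridin-2-yl on compound 3

The compounds below may be only part of what the source reports. "The series", "measured", "known", "first", "only" and "open" are said of these compounds alone.

In a functional assay for inhibition, with Homo sapiens as the target (a higher number here means a weaker inhibitor, a lower number a stronger inhibitor), compound 3 `NS(=O)(=O)c1cccc(Nc2nccc(-c3ccncc3)n2)c1` gives 500 nM, which lies within the scatter of compound 1 `c1ccc(-c2ccnc(Nc3cccc(OCCn4ccnc4)c3)n2)nc1` at 400 nM and of compound 2 `Cc1cccc(Nc2nccc(-c3ccccn3)n2)c1` at 700 nM. Compound 4 `NS(=O)(=O)c1cccc(Nc2nccc(-c3ccccn3)n2)c1` carries pyridin-2-yl in place of pyridin-4-yl on an aromatic carbon. Within the data shown here, no measured step tests this exchange. The only one, a 1.8-fold higher number from compound 1 to compound 2 (0.24 log units; within the scatter), is methyl in place of 2-(1H-imidazol-1-yl)ethoxy on an aromatic carbon, with pyridin-2-yl present on both sides, and it lies within the scatter. Compound 2, with pyridin-2-yl, gives 700 nM and compound 3 gives 500 nM, so no shift beyond the scatter is expected. The estimated change is a 1.1-fold higher number from compound 3 to compound 4 (0.04 log units; within the scatter). Compound 4 is estimated at 550 nM, with an expected range of 220 nM to 1300 nM.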

Compound 4, half-maximal inhibitory concentration: 500 nM
Beside the measured number, compound 4's estimate is 1.1-fold (0.04 log units) above it; measured number inside the range.
By their numbers in this assay, from the lowest: compounds 1, 3, 4 and 2 (each within the scatter of the next).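

In this assay, among these compounds, pyridin-2-yl in place of pyridin-4-yl, tested directly here for the first time with sulfamoyl held fixed, leaves the number unmoved (no change at the digits printed from compound 3 to compound 4 (within the scatter)). With pyridin-2-yl held fixed, sulfamoyl in place of methyl (a 1.4-fold lower number from compound 2 to compound 4 (0.15 log units; within the scatter)) and sulfamoyl in place of 2-(1H-imidazol-1-yl)ethoxy (a 1.3-fold higher number from compound 1 to compound 4 (0.10 log units; within the scatter)) also stay within the scatter. Nothing available accounts for this flatness.

From the compounds shown here alone, whether pyridin-3-yl or phenyl at this position would shift the number beyond the scatter remains open. The same holds for an amine or a carboxylic acid in place of sulfamoyl.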